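The source may hold more compounds than are shown below. What is called first, only, known or untested is meant among the compounds shown, and "the series" means these compounds.

In an ADME assay on BEAS-2B cells (Homo sapiens) for cytotoxicity, read by fluorescence, with a stated time of 48 h (on this read-out lower numbers stand for higher toxicity in this test and higher numbers for lower toxicity in this test), compound 1 `O=C(Nc1ccccc1)c1cc2n(n1)CCCN(C(=O)c1occc1Cl)C2` gives 30000 nM. Compound 2 `O=C(Nc1ccccc1)c1cc2n(n1)CCCN(C(=O)c1occc1C(F)(F)F)C2` gives 30000 nM in the same test. Compound 3 `Cc1coc(C(=O)N2CCCn3nc(C(=O)Nc4ccccc4)cc3C2)c1C` gives 30000 nM in this assay.

Compound 3 therefore stands level with compounds 1 and 2 at the digits shown: the step of no change at the digits printed from compound 1 to compound 3 (within the scatter) and the step of no change at the digits printed from compound 2 to compound 3 (within the scatter) both lie within the scatter, as does the step of no change at the digits printed from compound 1 to compound 2 (within the scatter) between the two other compounds. Each of these three steps exchanges the group that sits on the carbonyl carbon attached to the ring nitrogen of the shared core, and none of them moved the read-out in this assay beyond the scatter.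

Compound 4 `Cc1cc(C)c(C(=O)N2CCCn3nc(C(=O)Nc4ccccc4)cc3C2)o1` differs from compound 3 in the same place: 3,5-dimethylfuran-2-yl in place of 3,4-dimethylfuran-2-yl on a carbonyl carbon. Since every measured exchange at this carbonyl carbon left the read-out unchanged within the scatter, no step beyond the scatter is expected here either, and the expected step is no change at the digits printed from compound 3 to compound 4 (within the scatter). Compound 4 is thus estimated to give 30000 nM in this assay, with an expected range from 15000 nM to 60000 nM.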

Compound 4, half-maximal cytotoxic concentration: 2600 nM
The estimate for compound 4 lay 12-fold (1.06 log units) above the measured number; measured number outside the range, below it.
By their numbers in this assay, from the lowest: compound 4; then compounds 1, 2 and 3 (each within the scatter of the next).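

For the compounds shown here, at the carbonyl carbon of the shared core, this assay does respond to the group attached: with the same atoms joined differently, a 12-fold lower number from compound 3 to compound 4 (1.06 log units; beyond the scatter) shows that the unchanged numbers among the earlier compounds did not mean that every group here behaves alike. The other two comparisons agree, with a 12-fold lower number from compound 2 to compound 4 (1.06 log units; beyond the scatter) and a 12-fold lower number from compound 1 to compound 4 (1.06 log units; beyond the scatter) in this test, so the 3,5-dimethylfuran-2-yl group stands apart from the three other furans, and compound 4 is the most toxic of the four in this test. Nothing measured here explains why this one exchange moves the read-out.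

The compounds shown leave open whether the effect is specific to this dimethylfuran. A methylfuran, a phenyl ring or an amine-bearing group on this carbonyl carbon could fall with compound 4 or level with compounds 1, 2 and 3.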